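The source may report more compounds than this note shows. Statements on the series, on what has been measured and on what is new or still open speak of the compounds shown alone.

Compound 1 `COc1cc(/C=C/C(=O)c2cccc(NC(=O)c3cccs3)c2)ccc1O` and compound 2 `COC(=O)C(=O)Nc1cccc(C(=O)/C=C/c2ccc(O)c(OC)c2)c1` share one core and differ only at the carbonyl carbon of the amide. In a functional assay on HUVEC cells (Homo sapiens) for inhibition, tested at 5 ug/mL (on this read-out lower numbers stand for a weaker effect and higher numbers for a stronger effect at the one concentration tested), compound 1 gives 80%, whereas compound 2 gives 20%. That is the lowest of the two numbers shown, and the step of a number 60 percentage points lower from compound 1 to compound 2 (beyond the scatter) lies well beyond the scatter.

Compound 3 `COc1cc(/C=C/C(=O)c2cccc(NC(C)=O)c2)ccc1O` has not yet been measured. It differs from compound 2 in one place: methyl in place of methoxycarbonyl on a carbonyl carbon. Within the data shown here, no measured step bears directly on this change; the only step known is the one from compound 1 to compound 2, where the methoxycarbonyl group arrived and the number fell sharply. Since compound 3 removes that same methoxycarbonyl group again, though it puts a methyl rather than the thiophen-2-yl group of compound 1 in its place, some recovery is expected in this assay, but its size is uncertain.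

For compound 3 the expected value is 45%, within a range from 20% to 75%. The step this estimate means, a number 25 percentage points higher from compound 2 to compound 3 (beyond the scatter), is expected to be upward and beyond the scatter.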

Compound 3, a percentage reported as inhibition, at one concentration (the size of the read-out at that concentration, not a potency): 15%
Compound 3: the middle estimate sits 30 percentage points above what was measured, outside the stated range (below it).
By their numbers in this assay, from the lowest: compounds 3 and 2 (each within the scatter of the next); then compound 1.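

In this assay, putting methyl in place of methoxycarbonyl on the carbonyl carbon gives a number 5 percentage points lower from compound 2 to compound 3 (within the scatter), so the low number of compound 2 does not depend on the methoxycarbonyl group, since the much smaller methyl leaves the read-out within the scatter. The change from the thiophen-2-yl group to methyl gives a number 65 percentage points lower from compound 1 to compound 3 (beyond the scatter), a large step of the same kind as a number 60 percentage points lower from compound 1 to compound 2 (beyond the scatter), so among these three compounds the high number goes with the thiophen-2-yl group of compound 1 alone, and the two groups without a ring stay together at the low end. Nothing at hand explains why this group stands apart from the other two.

These compounds leave open whether the high number needs thiophen-2-yl itself or would also appear with another ring on the same carbonyl carbon, such as phenyl or furan-2-yl, or with a longer chain such as butyl. Since the read-out comes from a single concentration, it also leaves open how far compound 1 stands from compound 2 and compound 3 in potency.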